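Piperazine substituent change from compound 2 to compound 3

The source may report more compounds than this note shows. Statements on the series, on what has been measured and on what is new or still open speak of the compounds shown alone.

Measured so far:
compound 1, `CCN1CCN(CCC(=O)Nc2nc3c(C)cccc3s2)CC1`: 1200 nM in an assay on membranes from liver for displacement of a labelled ligand from Sigma intracellular receptor 2 (Rattus norvegicus), read by scintillation counting, with a stated time of 120 min; a higher number here means a weaker inhibitor, a lower number a stronger inhibitor
compound 2, `Cc1cccc2sc(NC(=O)CCN3CCN(c4ccccn4)CC3)nc12`: > 1000 nM in this assay

Compound 2 stands only at a limit in this assay, so its position is bounded on one side, not fixed. Compound 1 has a measured value, but a step that the limit leaves unreadable from compound 1 to compound 2 cannot be sized because of the limit of > 1000 nM in this assay, at which 1 of the 2 values shown sits.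

Compound 3, `Cc1cccc2sc(NC(=O)CCN3CCN(c4ccncc4)CC3)nc12`, differs from compound 2 by pyridin-4-yl in place of pyridin-2-yl on an amine nitrogen in a ring. Among the compounds with values here, no measured step bears on this change: the single step, from ethyl to pyridin-2-yl, is itself unreadable, and nothing shows how moving the ring nitrogen within the pyridinyl group acts in this assay. No step beyond the scatter is therefore expected in either direction, and a limit is again likely. The value of compound 3 is estimated at 2500 nM, within 600 nM to 10000 nM, which is expected to mean a step that the limit leaves unreadable from compound 2 to compound 3 from compound 2.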

Compound 3, inhibition constant: 1700 nM
Beside the measured number, compound 3's estimate is 1.5-fold (0.17 log units) above it; measured number inside the range.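

In this assay, pyridin-4-yl in place of ethyl on the amine nitrogen in the ring gives a 1.4-fold higher number from compound 1 to compound 3 (0.15 log units; within the scatter), so this position now has a measured comparison between a pyridinyl group and ethyl, and the two cannot be told apart. Within the data shown here, this is the first sign that a pyridinyl group at this position can carry a measured value rather than a limit. For compound 2 the value of > 1000 nM is a limit, and the steps that involve compound 2 cannot be read: the limit of > 1000 nM in this assay, at which 1 of the 3 values shown sits.

As far as these compounds go, whether the place of the nitrogen within the pyridinyl group matters at this position therefore stays open. Also open, from the compounds shown here alone, is whether a different group on this nitrogen, such as benzyl or acetyl, would give a step beyond the scatter.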